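This account rests on a few compounds, and the source may have more. Where it says the series, first, only, none or still open, it means among the compounds named here.

Three compounds sharing the core of compound 1 `COc1cc(N)c(Cl)cc1C(=O)CCC1CCN(CCNS(=O)(=O)c2cc(Br)c(N)c(Br)c2)CC1` have been measured in an assay on brain for displacement of a labelled ligand from 5-hydroxytryptamine receptor 4 (Cavia porcellus), with a stated time of 30 min, in the presence of a further agent that is not named here; a lower number here means a stronger inhibitor, a higher number a weaker inhibitor. Compound 1 gives 8.7 nM, the lowest of the three numbers, though the other two sit within the usual scatter of it: compound 3 `COc1ccc(S(=O)(=O)CCCN2CCC(CCC(=O)c3cc(Cl)c(N)cc3OC)CC2)cc1` gives 12.2 nM in this assay, and compound 2 `COc1cc(N)c(Cl)cc1C(=O)CCC1CCN(CCNS(=O)(=O)c2cc(Br)ccc2Br)CC1` gives 16.3 nM. Compound 2 differs from compound 1 in one place only, and that step, a 1.9-fold higher number from compound 1 to compound 2 (0.27 log units; within the scatter), stays within the scatter.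

Compound 4 `COc1ccc(S(=O)(=O)NCCN2CCC(CCC(=O)c3cc(Cl)c(N)cc3OC)CC2)cc1OC` has not been measured yet. It differs from compound 1 at the same position, the sulfonyl sulfur: 3,4-dimethoxyphenyl in place of 4-amino-3,5-dibromophenyl on a sulfonyl sulfur. Among the measured compounds shown here, the one measured step that touches this position is the exchange of the aryl group on the sulfonyl sulfur, which gave a 1.9-fold higher number from compound 1 to compound 2 (0.27 log units; within the scatter), so no change beyond the scatter. Compound 3 differs from compound 1 in more than one place, so only its value can be set beside that of compound 1, and the two lie within the scatter of each other. A further exchange of the aryl group at this position is therefore expected to leave the number close to where compound 1 stands, and the expected step is a 1.4-fold higher number from compound 1 to compound 4 (0.14 log units; within the scatter). Compound 4 is estimated at 12 nM, with a range from 4 nM to 36 nM.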

Compound 4, inhibition constant: 8.2 nM
Beside the measured number, compound 4's estimate is 1.5-fold (0.17 log units) above it; measured number inside the range.
By their numbers in this assay, from the lowest: compounds 4, 1, 3 and 2 (each within the scatter of the next).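

Among the compounds shown here, the earlier one-place step compared only two aryl groups that both carry bromine, so it could not show whether bromine matters at this position. Compound 4 has none: in this assay, 3,4-dimethoxyphenyl in place of 4-amino-3,5-dibromophenyl on the sulfonyl sulfur gives a 1.1-fold lower number from compound 1 to compound 4 (0.03 log units; within the scatter), and 3,4-dimethoxyphenyl in place of 2,5-dibromophenyl gives a 2.0-fold lower number from compound 2 to compound 4 (0.30 log units; within the scatter), so among these three aryl groups, losing the bromine atoms does not move the number beyond the scatter. No measurement of any other kind accompanies these numbers to explain this result.

From the compounds shown here alone, all three groups compared at this position are substituted phenyl rings, so it remains open whether a cyclohexyl ring or a plain methyl group on the sulfonyl sulfur would keep the number in the same range. A phenyl ring carrying a carboxylic acid or an aminomethyl group is a further open case, and such a change would test how much variety this position accepts in this assay.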